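Swapping One Side Chain on a Shared Core

The compounds below may be only part of what the source reports. "The series", "measured", "known", "first", "only" and "open" are said of these compounds alone.

- Compound 1 `COc1ccccc1OCC1SCCN1C(=O)CNc1cc(Br)cc(Br)c1O`: 20 mg/kg
- Compound 2 `COc1ccccc1OCC1SCCN1C(=O)COC(C)=O`: 25 mg/kg
- Compound 3 `CCOC(=O)CC(=O)N1CC[S+]([O-])C1COc1ccccc1OC`: 28 mg/kg

These values all come from a functional assay on the whole organism (trachea) for inhibition, with Cavia porcellus as the target; on this read-out lower numbers stand for an effect already at smaller amounts and higher numbers for an effect only at larger amounts of compound. On these numbers, compound 2 at 25 mg/kg cannot be told apart from compound 1 at 20 mg/kg or from compound 3 at 28 mg/kg, since repeated measurements of this kind scatter by about as much as these values differ.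

The next compound to be tested is compound 4 `CCOC(=O)C(C)(C)C(=O)N1CCSC1COc1ccccc1OC`. It differs from compound 2 by one structural change: 1-(ethoxycarbonyl)-1-methylethyl in place of acetoxymethyl on a carbonyl carbon. In words, 1-(ethoxycarbonyl)-1-methylethyl stands in place of acetoxymethyl on a carbonyl carbon.

For the measured compounds named here, no two measured compounds differ in only one place, so no measured step shows directly what such a swap does. Going by the values given here, the only guide is the overall spread. Compound 1 at 20 mg/kg and compound 3 at 28 mg/kg carry different groups on that carbonyl carbon, yet their values lie within the scatter of each other. Three compounds are a thin basis, so the expectation remains loose, and no change beyond the scatter is expected. The estimated change is a 1.1-fold higher number from compound 2 to compound 4 (0.05 log units; within the scatter). In this assay the estimate for compound 4 is 28 mg/kg, with an expected range from 11 mg/kg to 70 mg/kg.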

Compound 4, dose for half-maximal effect: 48 mg/kg
Compound 4: the middle estimate sits 1.7-fold (0.23 log units) below what was measured; measured number inside the range.
By their numbers in this assay, from the lowest: compounds 1, 2, 3 and 4 (each within the scatter of the next, the first and the last beyond it).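

For the compounds shown here, compound 4 gives the first measured comparison in which only the group on the carbonyl carbon differs: in this assay, 1-(ethoxycarbonyl)-1-methylethyl in place of acetoxymethyl gives a 1.9-fold higher number from compound 2 to compound 4 (0.28 log units; within the scatter). The entering group has 8 heavy atoms and the leaving group 5, while both have 2 hydrogen-bond acceptors and 0 donors, so at this position, in this one pair, a larger group with the same counts of acceptors and donors cannot be told apart from the smaller one on this read-out. No measurement presented here offers an explanation for how these two compounds read.

This single step says little about groups of a different kind, and an amine or a carboxylic acid on the same carbonyl carbon could still give a number beyond the scatter. On these data alone, a longer chain at this position is also open, as is whether the same swap would read the same way on a different core.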